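The compounds below may be only part of what the source reports. "The series", "measured", "known", "first", "only" and "open" are said of these compounds alone.

In an ADME assay (liver, Mus musculus) for metabolic stability, read by LC-MS, using microsomes, tested at 1 uM (a lower number here means that the compound disappears faster, a higher number that the compound lasts longer), compound 1 `C/C(=N/c1ccnc2cc(Cl)ccc12)NCCCN1CCCCC1` gives 0.417 h and compound 3 `CC(C)/C(=N/c1ccnc2cc(Cl)ccc12)NCCCN1CCCCC1` gives 0.717 h. Compound 2 `CN(C)CCCN/C(=N\c1ccnc2cc(Cl)ccc12)c1ccccc1` gives 0.867 h, a higher number than compound 1 shows. Compound 4 `CCN(CC)CCCCN/C(C)=N\c1ccnc2cc(Cl)ccc12` departs from compound 1 as follows: (diethylamino)methyl in place of piperidin-1-yl on a saturated chain carbon, three bonds along the chain from an amine nitrogen. The change sits on a saturated chain carbon, three bonds along the chain from an amine nitrogen. For the measured compounds named here, the only measured step in one place, a 1.7-fold higher number from compound 1 to compound 3 (0.24 log units; within the scatter), concerns a different group, so it serves only as a gauge of size, and no measured step touches this group. No shift beyond the scatter is therefore expected in this assay. The estimated step is a 1.1-fold higher number from compound 1 to compound 4 (0.03 log units; within the scatter). For compound 4 the expected half-life is 0.45 h, with an estimated range of 0.22 h to 0.9 h.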

Compound 4, half-life: > 1 h
Compound 4: a limit, no number; the forecaster's own chance of this, stated with the estimate: 3%; middle value at least 2.2-fold (0.34 log units) from the limit.
By their numbers in this assay, from the lowest: compounds 1, 3 and 2 (each within the scatter of the next, the first and the last beyond it). At a limit, above all of these: compound 4.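

In this assay, the saturated chain carbon three bonds along the chain from an amine nitrogen proves able to carry a change that moves the half-life: an at least 2.3-fold higher number from compound 1 to compound 4 (0.37 log units; beyond the scatter), whereas a 1.7-fold higher number from compound 1 to compound 3 (0.24 log units; within the scatter). Compound 4 carries a limit, not a number, so only the least size of this step can be read: the limit of > 1 h in this assay, at which 1 of the 4 values shown sits.

The change opens the ring and lengthens the chain together, and the compounds shown do not separate the two. From the compounds shown here alone, whether a diethylamino group on the chain of compound 1, or a piperidine ring on the chain of compound 4, would give the same half-life remains open.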